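This account rests on a few compounds, and the source may have more. Where it says the series, first, only, none or still open, it means among the compounds named here.

Three compounds sharing one core have numbers in a functional assay on HCT-116 cells (Homo sapiens) for antiproliferative activity, read by MTT assay, with a stated time of 72 h; a lower number here means a stronger inhibitor, a higher number a weaker inhibitor: compound 1 `NC1=NC2(CCOCC2)N(OCCCOc2ccccc2)C(N)=N1` gives 6010 nM, compound 2 `NC1=NC2(CCOCC2)N(OCCCOc2ccc(F)cc2)C(N)=N1` gives 3280 nM, and compound 3 `NC1=NC2(CCOCC2)N(OCCCOc2cccc(Cl)c2)C(N)=N1` gives 120 nM. Compound 3 has the lowest number of the three, and its gaps to both others lie beyond the scatter.

Compound 4 `NC1=NC2(CCOCC2)N(OCCCOc2ccc(Br)cc2)C(N)=N1` has not yet been measured. It differs from compound 3 as follows: 4-bromophenyl in place of 3-chlorophenyl on an oxygen on a saturated carbon. In short, 4-bromophenyl stands in place of 3-chlorophenyl on an oxygen on a saturated carbon.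

Within the data shown here, three measured steps bear on this change. Chloro in place of hydrogen gave a 50-fold lower number from compound 1 to compound 3 (1.70 log units; beyond the scatter), whereas fluoro in place of hydrogen gave only a 1.8-fold lower number from compound 1 to compound 2 (0.26 log units; within the scatter). Changing 4-fluorophenyl to 3-chlorophenyl gave a 27-fold lower number from compound 2 to compound 3 (1.44 log units; beyond the scatter). Among the measured compounds shown here, no bromo compound has been measured, so the 4-bromophenyl group may keep only part of the large gain seen with 3-chlorophenyl.

In this assay, a move to a higher number is therefore expected, estimated as a 6.7-fold higher number from compound 3 to compound 4 (0.82 log units; beyond the scatter). For compound 4, the estimated value is 800 nM, with an expected range from 150 nM to 3500 nM.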

Compound 4, half-maximal inhibitory concentration: 320 nM
Estimate against measurement, compound 4: 2.5-fold (0.40 log units) above; the range from low to high includes it.
By their numbers in this assay, from the lowest: compound 3; then compound 4; then compounds 2 and 1 (each within the scatter of the next).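

In this assay, a large gain is not unique to 3-chlorophenyl: bromo in place of hydrogen gives a 19-fold lower number from compound 1 to compound 4 (1.27 log units; beyond the scatter) and bromo in place of fluoro gives a 10-fold lower number from compound 2 to compound 4 (1.01 log units; beyond the scatter), so the choice of halogen on 4-substituted phenyl matters greatly. Replacing 3-chlorophenyl with 4-bromophenyl costs only a modest amount, with a 2.7-fold higher number from compound 3 to compound 4 (0.43 log units; beyond the scatter), and most of the gain over the unsubstituted phenyl survives. Nothing available explains these differences between the groups.

This change swaps the halogen and its ring location together, so the contribution of each stays unresolved. The 4-chlorophenyl and 3-bromophenyl groups would separate the two, while a longer chain in place of the propyl linker would test the other part of this side chain.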